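The compounds below may be only part of what the source reports. "The series", "measured", "known", "first", "only" and "open" are said of these compounds alone.

Measured in a functional assay on MCF7 cells (Homo sapiens) for inhibition, read by sulforhodamine B assay, with a stated time of 48 h; a lower number here means a stronger inhibitor of growth, a higher number a weaker inhibitor of growth:
- compound 1 `N#CCC1=C(C#N)CC(c2ccc(Br)cc2)=C(CC(=O)c2ccc(Br)cc2)O1`: 12000 nM
- compound 2 `N#CCC1=C(C#N)CC(c2ccc([N+](=O)[O-])cc2)=C(CC(=O)c2ccc([N+](=O)[O-])cc2)O1`: 30 nM

Of these two, compound 2 has the lower number, beyond the scatter from compound 1. Compound 3 `N#CCC1=C(C#N)CC(c2ccc(Br)cc2)=C(CC(=O)c2ccc([N+](=O)[O-])cc2)O1` departs from compound 2 at one place: bromo in place of nitro on an aromatic carbon, para to a large group. Compound 3 thus carries one nitro and one bromo. Compound 1, with bromo in both places, gives 12000 nM, so a higher number, beyond the scatter, is expected in this assay, lying between the two measured values. The expected change is a 20-fold higher number from compound 2 to compound 3 (1.30 log units; beyond the scatter). For compound 3 the estimated value is 600 nM, with an expected range of 80 nM to 5000 nM.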

Compound 3, concentration for 50% growth inhibition: 90 nM
Estimate against measurement, compound 3: 6.7-fold (0.82 log units) above; the measured number falls inside the stated range.
By their numbers in this assay, from the lowest: compound 2; then compound 3; then compound 1.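

In this assay the change from 4-nitrophenyl to 4-bromophenyl at this place gives only a 3.0-fold higher number from compound 2 to compound 3 (0.48 log units; beyond the scatter) while nitro in place of bromo on the other aromatic ring, the one carrying the carbonyl, gives a 130-fold lower number from compound 1 to compound 3 (2.12 log units; beyond the scatter) and so is the far larger step. The two aromatic rings therefore do not count equally, and a bromo group is tolerated much better at this place than at the other. Nothing available explains this difference between the two places.

From the compounds shown here alone, it remains open whether an amine or a methoxy group at this place would keep the number as low as nitro or bromo does. The compounds shown also leave open how a chloro group would compare on the ring carrying the carbonyl.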